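This account rests on a few compounds, and the source may have more. Where it says the series, first, only, none or still open, it means among the compounds named here.

Among the compounds with values here, compound 2 `O=C(CN(c1nc(Cl)nc2[nH]cnc12)C1CC1)N[C@@H](CC(=O)OCc1ccccc1)C(=O)OCc1ccccc1` stands lowest of the two numbers measured in a functional assay on the whole organism (Tail, strain ICR) with Mus musculus as the target, in the tail flick test, with a stated time of 60 min, at a dose of 25 umol/kg by the oral route (on this read-out higher numbers stand for a stronger effect at the one dose given and lower numbers for a weaker effect), where compound 2 gives 22.4%; compound 1 `C[C@H](NC(=O)CN(c1nc(Cl)nc2[nH]cnc12)C1CC1)C(=O)OCc1ccccc1` gives 64.3%, and the only step recorded, a number 41.9 percentage points lower from compound 1 to compound 2 (beyond the scatter), came with benzyloxycarbonyl in place of hydrogen. Compound 3 `O=C(CN(c1nc(Cl)nc2[nH]cnc12)C1CC1)N[C@@H](CCC(=O)OCc1ccccc1)C(=O)OCc1ccccc1` extends that same chain by one carbon: (benzyloxycarbonyl)methyl in place of benzyloxycarbonyl on a saturated chain carbon, two bonds along the chain from an amide-type nitrogen and a carbonyl carbon. Within the data shown here, no measured step covers a homologation of this kind, so the one large drop from compound 1 to compound 2 gives only a setting, not a direction. In this assay compound 3 is expected to stay near compound 2, the step of a number 3.6 percentage points higher from compound 2 to compound 3 (within the scatter) expected to lie within the scatter. The estimate for compound 3 is 26%, range 8% to 50%.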

Compound 3, a percentage reported as activity, at one dose (the size of the read-out at that dose, not a potency): 53.7%
The estimate for compound 3 lay 27.7 percentage points below the measured number; the measured number lies above the stated range.
By their numbers in this assay, from the lowest: compound 2; then compound 3; then compound 1.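

At this position the length of the side chain counts in this assay: (benzyloxycarbonyl)methyl in place of benzyloxycarbonyl gives a number 31.3 percentage points higher from compound 2 to compound 3 (beyond the scatter) and so shows that the low number of compound 2 does not hold for every benzyloxycarbonyl-ended group here. Against hydrogen, the same longer group gives only a number 10.6 percentage points lower from compound 1 to compound 3 (beyond the scatter) and so recovers most of the number lost with benzyloxycarbonyl. Within the data shown here, no measured evidence bears on why this change moves the number so far.

Still open, going by these compounds, is whether a longer chain such as 3-(benzyloxycarbonyl)propyl holds this level. A free carboxylic acid or an amine at the chain end also remains to be placed against these groups.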